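A few compounds are considered here, and "the series" means these few. Any claim that something is new, unique, unknown or untested is made for them only; others in the source may bear on it.

Of the compounds shown here, two of a shared urea core have been measured so far. Compound 1 `O=C(Nc1ccc(-n2ncc3c(Cl)cccc32)cc1)Nc1ccc(Cl)c(C(F)(F)F)c1` gives 1300 nM in a functional assay on NCI-H460 cells (Homo sapiens) for cytotoxicity, read by MTT assay, with a stated time of 72 h; a higher number here means a weaker inhibitor, a lower number a stronger inhibitor. Compound 2 `Cc1cccc2c1cnn2-c1ccc(NC(=O)Nc2ccc(Cl)c(C(F)(F)F)c2)cc1` differs only by a methyl in place of the chloro on one aromatic carbon, and in this assay compound 2 gives 2500 nM. The step of a 1.9-fold higher number from compound 1 to compound 2 (0.28 log units; within the scatter) shows that these two numbers sit within the usual scatter of each other, so neither compound is set apart from the other on the evidence at hand; compound 2 is simply one of the two measured points.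

Compound 3 `CNc1cccc2c1cnn2-c1ccc(NC(=O)Nc2ccc(Cl)c(C(F)(F)F)c2)cc1` is not yet measured. It differs from compound 2 by methylamino in place of methyl on an aromatic carbon. Among the measured compounds shown here, no measured step bears directly on such a change, since the only step available, from a chloro to a methyl, is within the scatter and involves neither a hydrogen-bond donor nor an acceptor. The expectation therefore rests on compound 2 alone, and the expected step of no change at the digits printed from compound 2 to compound 3 (within the scatter) is none beyond the scatter. Compound 3 is estimated to give 2500 nM in this assay, with a range from 900 nM to 7000 nM.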

Compound 3, half-maximal inhibitory concentration: 2600 nM
Compound 3: middle estimate off by 1.0-fold (0.02 log units), on the low side; the range from low to high includes it.
By their numbers in this assay, from the lowest: compounds 1, 2 and 3 (each within the scatter of the next).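

In this assay, among the compounds shown here, methylamino in place of methyl on this aromatic carbon gives a 1.0-fold higher number from compound 2 to compound 3 (0.02 log units; within the scatter), and this is the first change at this place that brings in a hydrogen-bond donor and a hydrogen-bond acceptor, yet the numbers cannot be told apart. Methylamino in place of chloro gives a 2.0-fold higher number from compound 1 to compound 3 (0.30 log units; within the scatter), so chloro, methyl and methylamino, which differ in size and in what they carry, all sit within the scatter of one another at this place and this cell-based read-out does not separate them. Nothing measured here explains why the three groups give numbers so alike.

A free amine, a carboxylic acid or a longer chain such as a butylamino group at this carbon could still show whether this place accepts any group or only ones of modest size. The compounds shown also leave open how much the chloro and trifluoromethyl groups elsewhere in the shared core contribute, since both stay the same throughout.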